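Carboxy to Carbamoyl on the Acid Amidase Inhibitor Core

The compounds below may be only part of what the source reports. "The series", "measured", "known", "first", "only" and "open" are said of these compounds alone.

compound 1 `O=C(CCCCCc1cccc(I)c1)N1CCOC1=O` — 3120 nM
compound 2 `COc1cccc(CCCCCC(=O)N2CCOC2=O)c1` — 16300 nM
compound 3 `O=C(O)c1cccc(CCCCCC(=O)N2CCOC2=O)c1` — a limit of the assay, > 20000 nM

The three measured compounds share one core and differ only in the substituent on the aromatic ring. In an assay on HEK293 cells for inhibition of N-acylethanolamine-hydrolyzing acid amidase (Rattus norvegicus), read by LC-MS, with a stated time of 30 min (on this read-out lower numbers stand for stronger inhibition and higher numbers for weaker inhibition), compound 1 gives 3120 nM. Replacing the iodo group by a methoxy group, the step of a 5.2-fold higher number from compound 1 to compound 2 (0.72 log units; beyond the scatter), weakens inhibition. Compound 3 carries a carboxy group, and for compound 3 the assay reports only a limit, > 20000 nM. The step of an at least 6.4-fold higher number from compound 1 to compound 3 (0.80 log units; beyond the scatter) is therefore known only as a floor, and so is the step of an at least 1.2-fold higher number from compound 2 to compound 3 (0.08 log units; that floor lies within the scatter). Compound 3 thus stands not at a number but at the boundary past which this assay gives none (the limit of > 20000 nM in this assay, at which 1 of the 3 values shown sits).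

Compound 4 `NC(=O)c1cccc(CCCCCC(=O)N2CCOC2=O)c1` is not yet measured. It differs from compound 3 by amino in place of hydroxy on a carbonyl carbon. Within the data shown here, no measured step alters anything on the carbonyl carbon, so none bears directly on this change; the steps to compound 3 show only that the carboxy compound lies at or past the limit. Compound 4 is expected to stay weak, with an estimated step of an at least 1.3-fold lower number from compound 3 to compound 4 (0.12 log units; that floor lies within the scatter) that cannot be fixed against a limit. For compound 4 the estimate is 15000 nM, within a range from 5000 nM to 40000 nM, with a real chance that the assay again returns only a limit.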

Compound 4, half-maximal inhibitory concentration: > 20000 nM
Compound 4: no number, only a limit; the forecaster's own chance of this, stated with the estimate: 45%; at least 1.3-fold (0.12 log units) between middle value and limit.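

In this assay compound 4 returns only a limit, > 20000 nM, so the carbamoyl group joins the carboxy group at the boundary of what the read-out can report: the limit of > 20000 nM in this assay, at which 2 of the 4 values shown sit. With carbamoyl in place of iodo on the aromatic carbon the change is an at least 6.4-fold higher number from compound 1 to compound 4 (0.80 log units; beyond the scatter), which marks a real loss, while with carbamoyl in place of methoxy it is an at least 1.2-fold higher number from compound 2 to compound 4 (0.08 log units; that floor lies within the scatter), which by itself establishes no difference. Among these compounds, the step of amino in place of hydroxy on the carbonyl carbon has limits at both ends and cannot be read, so what is new is only that this exchange does not bring a measurable number back.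

From the compounds shown here alone, how far compound 3 and compound 4 lie past the limit remains open, and with it any order between them. Also open, going by these compounds, is whether a group such as a nitrile, an amine or a bromo substituent on the aromatic ring of the shared core, or a longer chain, would return a number, and how that number would compare with the iodo compound.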